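The source may hold more compounds than are shown below. What is called first, only, known or untested is meant among the compounds shown, and "the series" means these compounds.

In a functional assay on HL-60 cells (Homo sapiens) for cytotoxicity, read by MTT assay, with a stated time of 72 h (a lower number here means a stronger inhibitor, a higher number a weaker inhibitor), compound 1 `COC(=O)c1sc2c(C)cccc2c1Nc1cc(OC)c(OC)c(OC)c1` gives 4270 nM. Compound 2 `COC(=O)c1sc2ncccc2c1Nc1cc(OC)c(OC)c(OC)c1` gives 2920 nM, which lies within the usual scatter of compound 1. Compound 3 `CCOC(=O)c1sc2cc(C)ccc2c1Nc1cc(OC)c(OC)c(OC)c1` gives 3.9 nM, a far lower number and well beyond the scatter from compound 1. Compound 1 therefore sits with compound 2 at the weak end of this small set, a long way from compound 3.

The next molecule, compound 4 `COC(=O)c1sc2ccccc2c1Nc1cc(OC)c(OC)c(OC)c1`, differs from compound 1 in a single place hydrogen in place of methyl on an aromatic carbon. Among the measured compounds shown here, no two measured compounds differ in only one place, so the data show no direct precedent for this swap. Compound 3 proves that very low numbers are possible among these molecules, but it differs from compound 1 in more than one place, so its result cannot simply be carried over.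

Removing one small group is expected to leave compound 4 much closer to compound 1, at 4270 nM, than to compound 3, at 3.9 nM. The expected change is modest, and the estimated step is a 2.8-fold lower number from compound 1 to compound 4 (0.45 log units; beyond the scatter). For compound 4, the estimate is 1500 nM, with an expected range from 150 nM to 8000 nM.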

Compound 4, half-maximal inhibitory concentration: 1540 nM
Compound 4: middle estimate off by 1.0-fold (0.01 log units), on the low side; the range from low to high includes it.
By their numbers in this assay, from the lowest: compound 3; then compounds 4, 2 and 1 (each within the scatter of the next, the first and the last beyond it).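

In this assay, putting hydrogen in place of methyl on this aromatic carbon gives a 2.8-fold lower number from compound 1 to compound 4 (0.44 log units; beyond the scatter). Among the compounds shown here, this is the first change in this set that can be read on its own, as only this one place differs. The step is modest but lies beyond the scatter, so at this position of the six-membered aromatic ring the methyl is not needed for cytotoxicity in these cells, and the compound without it has the lower number. No measurement shown here accounts for the direction or size of this step.

This single pair compares only methyl and hydrogen at one position, so it cannot show whether a chlorine atom, a methoxy group, an amine or a longer chain on the same carbon would lower the number further, raise it or leave it within the scatter. It also leaves open whether removing a methyl group from another carbon of the ring would give a similar step, and whether this step would keep its size with a different ester on the core.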